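Methoxy addition on two differently arranged cores

The source may report more compounds than this note shows. Statements on the series, on what has been measured and on what is new or still open speak of the compounds shown alone.

Compound 1 `COc1cc(OC)cc(-c2nc3cc(F)ccc3o2)c1` carries two methoxy groups on its pendant ring; in a functional assay on MCF7 cells (Homo sapiens) for inhibition (a lower number here means a stronger inhibitor, a higher number a weaker inhibitor), compound 1 gives 45400 nM. Compound 2 `COc1cc(-c2nc3cc(F)ccc3o2)cc(OC)c1OC` differs from it by methoxy in place of hydrogen on an aromatic carbon and in this assay compound 2 gives 16000 nM; the resulting step is a 2.8-fold lower number from compound 1 to compound 2 (0.45 log units; beyond the scatter). Compound 3 `COc1cc(OC)cc(-c2nc3ccc(F)cc3o2)c1` has the same atoms as compound 1 joined differently; the difference between the two cores is not broken down here. In this assay compound 3 gives 3720 nM, the lowest number of the three measured, with its steps to compound 1 and compound 2 both beyond the scatter. Compound 4 `COc1cc(-c2nc3ccc(F)cc3o2)cc(OC)c1OC` is still to be measured in this assay; it differs from compound 3 by methoxy in place of hydrogen on an aromatic carbon, the same change as from compound 1 to compound 2, at a place described in the same words. Among the measured compounds shown here, the step expected here is a 2.9-fold lower number from compound 3 to compound 4 (0.46 log units; beyond the scatter), resting on the single earlier instance a 2.8-fold lower number from compound 1 to compound 2 (0.45 log units; beyond the scatter), with the caution that one occurrence on another core is thin ground. Compound 4 is accordingly estimated at 1300 nM, with a range from 550 nM to 3200 nM.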

Compound 4, half-maximal inhibitory concentration: 1090 nM
Beside the measured number, compound 4's estimate is 1.2-fold (0.08 log units) above it, and the stated range covers the measured number.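

In this assay, methoxy in place of hydrogen on an aromatic carbon gives a 3.4-fold lower number from compound 3 to compound 4 (0.53 log units; beyond the scatter) on the second core, so the change carries across with a step of like size on both cores: the same change on two cores in this assay, a 2.8-fold lower number (0.45 log units; beyond the scatter) from compound 1 to compound 2 and a 3.4-fold lower number (0.53 log units; beyond the scatter) from compound 3 to compound 4, 1.2-fold (0.08 log units) apart, within the scatter of two such steps

Among the compounds shown here, this agreement rests on only two matched pairs, and both cores carry the same substituents on the fused system, joined differently. It supports carrying this one change between these two cores in this one assay, but it does not show that the step would hold on any other core. It also gives no reason for the lower number, and it does not break down the difference between the cores themselves.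

From the compounds shown here alone, whether another group in the same place, such as ethoxy, a hydroxyl or an amine, would give a step of similar size remains open. Also open, going by these compounds, is whether the step would persist with the fluorine replaced by chlorine or by a nitrile.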